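The source may report more compounds than this note shows. Statements on the series, on what has been measured and on what is new or still open speak of the compounds shown alone.

Measured in a functional assay on MCF7 cells (Homo sapiens) for antiproliferative activity, read by MTT assay, with a stated time of 72 h; a higher number here means a weaker inhibitor, a lower number a stronger inhibitor:
- compound 1 `CC(=O)O[C@H]1CC[C@]2(C)[C@H](CC[C@@](C)(O)[C@H]2CC[C@@H]2C(C)=CC[C@H]3[C@H](CC[C@]3(C)O)C2(C)C)OC1(C)C`: 47900 nM
- compound 2 `CC1=CC[C@H]2[C@H](CC[C@]2(C)O)C(C)(C)[C@@H]1CC[C@H]1[C@]2(C)CC[C@H](OC(=O)NCc3ccccc3)C(C)(C)O[C@H]2CC[C@@]1(C)O`: 24500 nM

With only these two compounds measured, compound 2 cannot be separated from compound 1. Going by the values given here, the single measured step is a 2.0-fold lower number from compound 1 to compound 2 (0.29 log units; within the scatter).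

Compound 3 `CC1=CC[C@H]2[C@H](CC[C@]2(C)O)C(C)(C)[C@@H]1CC[C@H]1[C@]2(C)CC[C@H](OC(=O)c3ccc(F)cc3)C(C)(C)O[C@H]2CC[C@@]1(C)O` shares the core of compound 2 and differs at one place: 4-fluorophenyl in place of benzylamino on a carbonyl carbon. In words, this is 4-fluorophenyl in place of benzylamino on a carbonyl carbon.

Among the compounds with values here, the one measured step bears on this change, since it also exchanged the group on that carbonyl carbon, and its size stayed within the scatter. Within the data shown here, it is only one step, and no measured compound yet carries 4-fluorophenyl. No step beyond the scatter is therefore expected in this assay. The expected change is a 1.2-fold higher number from compound 2 to compound 3 (0.09 log units; within the scatter). For compound 3 the estimated value is 30000 nM, with an expected range from 12000 nM to 70000 nM.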

Compound 3, half-maximal inhibitory concentration: 33500 nM
Beside the measured number, compound 3's estimate is 1.1-fold (0.05 log units) below it; low and high end bracket the measured number.
By their numbers in this assay, from the lowest: compounds 2, 3 and 1 (each within the scatter of the next).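

In this assay, the exchange of benzylamino for 4-fluorophenyl on the carbonyl carbon gives a 1.4-fold higher number from compound 2 to compound 3 (0.14 log units; within the scatter), and the exchange of methyl for 4-fluorophenyl gives a 1.4-fold lower number from compound 1 to compound 3 (0.16 log units; within the scatter). The position has now carried three different groups, an aromatic ring attached directly to the carbonyl carbon among them, and no pair of these compounds is separated; the hydrogen-bond donor of benzylamino, absent from 4-fluorophenyl, also brings no step beyond the scatter. No measurement shown here accounts for how close these numbers lie.

The compounds shown leave open whether any group on this carbonyl carbon can move the number beyond the scatter. A basic amine, a carboxylic acid or a longer alkyl chain at this place would test that.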